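The source may hold more compounds than are shown below. What is called first, only, known or untested is meant among the compounds shown, and "the series" means these compounds.

Of the compounds shown here, three have so far been measured in a functional assay on SW480 cells (Homo sapiens) for inhibition; on this read-out higher numbers stand for weaker inhibition of growth and lower numbers for stronger inhibition of growth. Compound 1 `Cc1c(C(=O)Nc2ccc3ccccc3n2)cnn1-c1ccccc1` gives 23900 nM. Compound 2 `Cc1c(C(=O)Nc2ccc3ccccc3n2)cnn1-c1c(F)cccc1Br` gives 3900 nM, the lowest of the three numbers, and compound 3 `CCc1ccccc1-n1ncc(C(=O)Nc2ccc3ccccc3n2)c1C` gives 9700 nM. Putting 2-bromo-6-fluorophenyl in place of phenyl on an aromatic nitrogen brings a 6.1-fold lower number from compound 1 to compound 2 (0.79 log units; beyond the scatter). Putting 2-ethylphenyl in its place brings a 2.5-fold higher number from compound 2 to compound 3 (0.40 log units; beyond the scatter), so compound 3 sits between the other two, as a 2.5-fold lower number from compound 1 to compound 3 (0.39 log units; beyond the scatter) also shows.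

Compound 4 `Cc1c(C(=O)Nc2ccc3ccccc3n2)cnn1-c1cccc(Cl)c1F` has not yet been measured. It differs from compound 2 in one place: 3-chloro-2-fluorophenyl in place of 2-bromo-6-fluorophenyl on an aromatic nitrogen. Both measured steps away from compound 1 show that a phenyl carrying groups gives a lower number than bare phenyl, and of the two the halogen-bearing phenyl of compound 2 gave the larger drop, seen in a 6.1-fold lower number from compound 1 to compound 2 (0.79 log units; beyond the scatter). Compound 4 keeps two halogens on that phenyl, but in a different arrangement and with chlorine instead of bromine, so some of the gain of compound 2 may be kept and some lost. The expected step is therefore a 1.8-fold higher number from compound 2 to compound 4 (0.25 log units; within the scatter), a modest rise. On this basis compound 4 is estimated at 7000 nM, within a range from 2500 nM to 20000 nM.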

Compound 4, concentration for 50% growth inhibition: 9000 nM
Compound 4: the middle estimate sits 1.3-fold (0.11 log units) below what was measured; measured number inside the range.
By their numbers in this assay, from the lowest: compound 2; then compounds 4 and 3 (each within the scatter of the next); then compound 1.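

In this assay, 3-chloro-2-fluorophenyl in place of 2-bromo-6-fluorophenyl brings a 2.3-fold higher number from compound 2 to compound 4 (0.36 log units; beyond the scatter), so two phenyl groups of equal heavy-atom count, each carrying fluorine and one other halogen, are not interchangeable at this position on the aromatic nitrogen. The new group still improves on bare phenyl, with a 2.7-fold lower number from compound 1 to compound 4 (0.42 log units; beyond the scatter), while a 1.1-fold lower number from compound 3 to compound 4 (0.03 log units; within the scatter) shows that it cannot be told apart from 2-ethylphenyl, so a halogen pair and a single ethyl group can give the same level of growth inhibition here, and only the 2-bromo-6-fluorophenyl of compound 2 stands clearly apart from bare phenyl and from both of these groups. Nothing available explains these differences in terms of how the groups act on the cells.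

Compound 2 and compound 4 differ at once in the second halogen and in where the halogens sit on the phenyl, so the compounds shown cannot separate the effect of bromine against chlorine from the effect of the arrangement. Also open, going by these compounds, is how a phenyl carrying a methoxy group or an amine would behave at this position.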